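The source may report more compounds than this note shows. Statements on the series, on what has been measured and on what is new or still open speak of the compounds shown alone.

Measured compounds:
- compound 1, `COC(=O)[C@@H](NC(=O)c1ccc(/C=C2\SC(=O)N(CC(=O)NOCc3ccccc3)C2=O)cc1)C(C)C` — in a functional assay on RAW264.7 cells (Mus musculus) for inhibition, read by microscopy and resazurin assay, with a stated time of 72 h (a higher number here means a weaker inhibitor, a lower number a stronger inhibitor), compound 1 gives a limit, > 128000 nM.
- compound 2, `CC(C)[C@H](NC(=O)CNC(=O)c1cn(CC(=O)NOCc2ccccc2)c2ccccc12)C(=O)O` — in this assay compound 2 gives a limit, > 128000 nM.
- compound 3, `C=CCONC(=O)Cn1ccc(C(=O)NCC(=O)N[C@@H](CC(C)C)C(=O)O)c1` — in this assay compound 3 gives a limit, > 128000 nM.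

Compound 3 stands at the limit of this assay, and so does every other value of the series: the limit of > 128000 nM in this assay, at which 3 of the 3 values shown sit. Among the compounds with values here, no measured value is a number, so no step between measured compounds can be given a size, and nothing distinguishes compound 3 from compound 1 or compound 2 on these numbers.

The next compound, compound 4, `C=CCONC(=O)Cn1ccc(C(=O)N[C@@H](C)C(=O)N[C@@H](CC(C)C)C(=O)O)c1`, is not yet measured in this assay. It differs from compound 3 in one place: methyl in place of hydrogen on a saturated chain carbon bound to an amide-type nitrogen and a carbonyl carbon. The rest of the structure, from the allyl-oxy hydroxamate through the shared core to the leucine acid, is kept.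

Within the data shown here, with no numerical step, the expectation for compound 4 is no change beyond the scatter, and the estimated step from compound 3 to compound 4 is a step that the limit leaves unreadable from compound 3 to compound 4. Compound 4 is therefore expected at about 200000 nM in this assay, with a range of 60000 nM to 700000 nM, and most likely it will again return only a limit.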

Compound 4, half-maximal inhibitory concentration: > 128000 nM
Compound 4: a limit, no number; the forecaster's own chance of this, stated with the estimate: 85%; the middle value is on the limit's open side.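

In this assay compound 4 gives > 128000 nM, which is a limit and not a number. Compound 3 also gives a limit, and no step can be read for the change from compound 3 to compound 4: the limit of > 128000 nM in this assay, at which 4 of the 4 values shown sit. The compounds shown leave open what size of effect, if any, methyl in place of hydrogen has at this place.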